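Swapping Fluoro for Methyl on the Amide Aryl Ring

The source may hold more compounds than are shown below. What is called first, only, known or untested is meant among the compounds shown, and "the series" means these compounds.

Compound 1, `Cc1ccc(C(=O)Nc2cc(-c3ccccc3)nn2-c2ccccc2)cc1`, gives 40 nM in an assay on isolated protein with metabotropic glutamate receptor 5 (Rattus norvegicus) as the target; a higher number here means that more compound is needed for the effect, a lower number that less compound is needed.
Compound 2, `O=C(Nc1cc(-c2ccccc2)nn1-c1ccccc1)c1cccc(F)c1`, gives 65 nM in this assay.

Going by the values given here, of these two numbers compound 2 has the higher one, but the only measured step, a 1.6-fold higher number from compound 1 to compound 2 (0.21 log units; within the scatter), lies within the scatter, so the two compounds cannot be told apart. Compound 3, `Cc1cccc(C(=O)Nc2cc(-c3ccccc3)nn2-c2ccccc2)c1`, differs from compound 2 by methyl in place of fluoro on an aromatic carbon. That single step is all that bears on this change, and because it was within the scatter, no shift beyond the scatter is expected in this assay. Compound 3 is therefore estimated at 50 nM, with a likely range from 20 nM to 130 nM. The expected step is a 1.3-fold lower number from compound 2 to compound 3 (0.11 log units; within the scatter).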

Compound 3, half-maximal effective concentration: 100 nM
The estimate for compound 3 lay 2.0-fold (0.30 log units) below the measured number, within the range that was stated.
By their numbers in this assay, from the lowest: compounds 1, 2 and 3 (each within the scatter of the next, the first and the last beyond it).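

In this assay the methyl-for-fluoro swap at this ring carbon gives a 1.5-fold higher number from compound 2 to compound 3 (0.19 log units; within the scatter) and so stays inside the scatter, which means these two groups cannot be told apart here. Moving the methyl, with 3-methylphenyl in place of 4-methylphenyl, gives a 2.5-fold higher number from compound 1 to compound 3 (0.40 log units; beyond the scatter) as the first step beyond the scatter, though a modest one, so where the methyl sits can shift the number. Nothing available explains that shift.

Still open, as far as these compounds go, is how a methoxy group, an amine or a carboxylic acid would behave on this ring carbon.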